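This account rests on a few compounds, and the source may have more. Where it says the series, first, only, none or still open, it means among the compounds named here.

Working notes on the series. In an ADME assay on MIA PaCa-2 cells (Homo sapiens) for cytotoxicity, read by MTT assay, with a stated time of 72 h (on this read-out lower numbers stand for stronger inhibition and higher numbers for weaker inhibition), compound 1 (`COc1ccc(OC)c(C2=C(c3cc(OC)c(OC)c(OC)c3)C(=O)CC2O[SiH2]C(C)(C)C)c1`) gives > 100 ug/mL as a limit of the assay, not a number. Compound 2 (`COc1ccc(C2=C(c3cc(OC)c(OC)c(OC)c3)CC(O)C2=O)cc1[N+](=O)[O-]`) gives > 100 ug/mL as a limit as well. Compound 3 (`COc1ccc(OC)c(C2=C(c3cc(OC)c(OC)c(OC)c3)C(=O)CC2O)c1`) gives > 100 ug/mL as a limit too. Compound 1 therefore has no readable place in the series, and the record so far is the limit of > 100 ug/mL in this assay, at which 3 of the 3 values shown sit, with no number among the results.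

Compound 4 (`COc1ccc(C2=C(c3cc(OC)c(OC)c(OC)c3)C(=O)CC2O[SiH2]C(C)(C)C)cc1O`) differs from compound 1 by 3-hydroxy-4-methoxyphenyl in place of 2,5-dimethoxyphenyl on a double-bonded ring carbon in a single exchange, 3-hydroxy-4-methoxyphenyl in place of 2,5-dimethoxyphenyl on a double-bonded ring carbon. Within the data shown here, the only measured step is a step that the two limits leave unreadable from compound 1 to compound 3 and it concerns the group on an oxygen on a saturated carbon, not this aryl exchange. It offers no size to carry over, so the expectation in this assay stays loose. The estimated move is an at least 3.3-fold lower number from compound 1 to compound 4 (0.52 log units; beyond the scatter) towards stronger inhibition, if a number is reported at all. For compound 4 the expected value is 30 ug/mL within an estimated range from 1 ug/mL to 100 ug/mL and a further limit remains quite possible.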

Compound 4, half-maximal inhibitory concentration: 55 ug/mL
Beside the measured number, compound 4's estimate is 1.8-fold (0.26 log units) below it; the measured number falls inside the stated range.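

In this assay, among these compounds, the exchange of 2,5-dimethoxyphenyl for 3-hydroxy-4-methoxyphenyl on a double-bonded ring carbon yields the first actual number, with compound 4 at 55 ug/mL. On these data alone, the step is an at least 1.8-fold lower number from compound 1 to compound 4 (0.25 log units; that floor lies within the scatter); it is a floor, so the full size of the exchange stays unknown. Compound 4 is the only compound with a number, and the others stay at the limit of the assay: the limit of > 100 ug/mL in this assay, at which 3 of the 4 values shown sit.

As far as these compounds go, the step from compound 1 to compound 3 cannot be read, so the role of the group on the oxygen on a saturated carbon stays open, including whether compound 4 would keep a number without it. Also open, from the compounds shown here alone, is which part of the aryl exchange carries the step, and whether an amine in place of the hydroxy group of 3-hydroxy-4-methoxyphenyl would give a number.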